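Replacing an aryl amide arm with isopentyl in a diacylhydrazine

The source may hold more compounds than are shown below. What is called first, only, known or untested is meant among the compounds shown, and "the series" means these compounds.

The three measured compounds share a diacylhydrazine core carrying a tert-butyl group on one nitrogen. Compound 1 `CC(C)(C)N(NC(=O)c1ccccc1)C(=O)c1ccccc1F` gives 309 nM in an assay on cells for agonist activity at ecdysone receptor (Bombyx mori), read by a luciferase reporter, with a stated time of 24 h; on this read-out lower numbers stand for an effect already at smaller amounts and higher numbers for an effect only at larger amounts of compound. Compound 2 `Cc1ccc(C(=O)NN(C(=O)c2ccccc2Cl)C(C)(C)C)cc1` gives 18.6 nM, and compound 3 `Cc1ccc(C(=O)NN(C(=O)c2cc(C)cc(C)c2)C(C)(C)C)cc1` gives 12 nM. Compound 3 thus has the lowest of the three numbers, though its gap to compound 2 is within the scatter, while compound 1 lies far higher. Going by the values given here, the only single-point step, a 1.6-fold lower number from compound 2 to compound 3 (0.19 log units; within the scatter), concerns the aryl group on the nitrogen that also bears the tert-butyl group.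

Compound 4 `Cc1cc(C)cc(C(=O)N(NC(=O)CCC(C)C)C(C)(C)C)c1` differs from compound 3 at the other carbonyl: isopentyl in place of 4-methylphenyl on a carbonyl carbon. Among the compounds with values here, no measured step touches this position, so the aryl groups of compounds 1 to 3 offer no direct guide for an alkyl chain there. Compound 4 is therefore expected to give a higher number than compound 3 in this assay, an estimated step of a 33-fold higher number from compound 3 to compound 4 (1.52 log units; beyond the scatter), with an estimate of 400 nM and a likely range from 80 nM to 3000 nM.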

Compound 4, half-maximal effective concentration: 91.2 nM
Compound 4: middle estimate off by 4.4-fold (0.64 log units), on the high side; measured number inside the range.
By their numbers in this assay, from the lowest: compounds 3 and 2 (each within the scatter of the next); then compound 4; then compound 1.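

In this assay, the carbonyl carbon that carries 4-methylphenyl in compound 3 also tolerates a chain with no ring: isopentyl gives a 7.6-fold higher number from compound 3 to compound 4 (0.88 log units; beyond the scatter) in this single change. The aromatic ring at this place can therefore be given up at a modest cost in this read-out, and compound 4 still gives 91.2 nM here. No measurement on hand explains the size of this step.

The compounds shown leave open whether the step follows from losing the ring or from this particular chain, which a shorter chain such as ethyl, a longer chain such as hexyl, or a saturated ring such as cyclohexyl at the same carbon could help to separate. Also open, as far as these compounds go, is whether isopentyl gives a similar step when 2-chlorophenyl sits on the other carbonyl.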